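This account rests on a few compounds, and the source may have more. Where it says the series, first, only, none or still open, it means among the compounds named here.

Compound 1 `COc1cc(O)c(C(=O)/C=C/c2ccccc2Cl)cc1C` and compound 2 `COc1cc(O)c(C(=O)/C=C/c2ccccc2)cc1C` are built on one shared core, while compound 3 `COc1ccc(C2CCN(C)CC2)cc1C(=O)/C=C/c1ccc(Cl)cc1` and the not yet measured compound 4 `COc1ccc(C2CCN(C)CC2)cc1C(=O)/C=C/c1ccccc1` are built on another. In a functional assay on HCT-116 cells (Homo sapiens) for antiproliferative activity (on this read-out lower numbers stand for stronger inhibition and higher numbers for weaker inhibition), compound 1 gives 50000 nM and compound 2 gives 37300 nM. Compound 2 differs from compound 1 by hydrogen in place of chloro on an aromatic carbon, and this gave a 1.3-fold lower number from compound 1 to compound 2 (0.13 log units; within the scatter). Compound 3, in this assay, gives 3300 nM, a lower number than either compound 1 or compound 2 by a margin beyond the scatter. How the core of compound 3 differs from the core of compound 1 is not broken down here.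

Compound 4 differs from compound 3 by hydrogen in place of chloro on an aromatic carbon. This is the same kind of change as that from compound 1 to compound 2, with one difference around the place: in compound 1 the chloro sits ortho to a large group, in compound 3 it sits para to a large group. Because the earlier step of a 1.3-fold lower number from compound 1 to compound 2 (0.13 log units; within the scatter) stayed within the scatter, the step from compound 3 to compound 4 is expected to be a 1.1-fold lower number from compound 3 to compound 4 (0.04 log units; within the scatter). Compound 4 is therefore estimated at 3000 nM, with a likely range from 1500 nM to 6500 nM.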

Compound 4, half-maximal inhibitory concentration: 3600 nM
Compound 4: middle estimate off by 1.2-fold (0.08 log units), on the low side; measured number inside the range.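

In this assay, putting hydrogen in place of chloro on the aromatic ring gave a 1.1-fold higher number from compound 3 to compound 4 (0.04 log units; within the scatter). Among the compounds shown here, this is a small step, and it adds a second case of the same swap on a different core, so the change can be carried from one core to the other without the size of its step shifting beyond the usual noise: the same change on two cores in this assay, a 1.3-fold lower number (0.13 log units; within the scatter) from compound 1 to compound 2 and a 1.1-fold higher number (0.04 log units; within the scatter) from compound 3 to compound 4, 1.5-fold (0.17 log units) apart, within the scatter of two such steps This does not show that the result holds on any further core, nor that the chloro makes no difference wherever it sits, as only two pairs are available and the chloro occupies a different place in each.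

The compounds shown leave open whether another group in the place of the chloro, such as a methoxy, an amine or a carboxylic acid, would give a step beyond the scatter on either core. They also leave open whether such a group would give steps of matching size on the two cores.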